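A few compounds are considered here, and "the series" means these few. Any claim that something is new, unique, unknown or untested is made for them only; others in the source may bear on it.

Within the data shown here, compound 3 `N#CC1=C(N)Oc2c(N)cc3nc4ccccc4nc3c2C12C(=O)N(Cc1cnnn1-c1cccc(C(F)(F)F)c1)c1ccccc12` is the only member of this small set that gives a number in a functional assay on A549 cells (Homo sapiens) for antiproliferative activity, read by MTT assay, with a stated time of 48 h; on this read-out higher numbers stand for weaker inhibition and lower numbers for stronger inhibition: compound 3 gives 5400 nM. Compound 1 `N#CC1=C(N)Oc2c(c3nc4ccccc4nc3c3ccccc23)C12C(=O)N(Cc1cnnn1-c1ccc(N)cc1)c1ccccc12` sits at a limit of the assay, where compound 1 gives > 50000 nM. Compound 2 `Cc1cc(C)cc(-n2nncc2CN2C(=O)C3(C(C#N)=C(N)Oc4c3c3nc5ccccc5nc3c3ccccc43)c3ccccc32)c1` likewise reaches only a limit, and compound 2 gives > 50000 nM. Among the measured compounds shown here, the one step between measured compounds that differ in a single place, a step that the two limits leave unreadable from compound 1 to compound 2, is therefore unreadable, because the limit of > 50000 nM in this assay, at which 2 of the 3 values shown sit, holds both ends of it. For the measured compounds named here, no step connects compound 3 to compound 1 or compound 2, since compound 3 carries a different core; the values show only that compound 3 gives a number where the other two do not.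

Compound 4 `CCc1cccc(CC)c1-n1nncc1CN1C(=O)C2(C(C#N)=C(N)Oc3c(N)cc4nc5ccccc5nc4c32)c2ccccc21` differs from compound 3 as follows: 2,6-diethylphenyl in place of 3-(trifluoromethyl)phenyl on an aromatic nitrogen. Going by the values given here, no measured step bears on this change: the only comparable exchange on the same aromatic nitrogen, from compound 1 to compound 2, is hidden behind a limit. With nothing to go on beyond the stand of compound 3, the expected step of a 1.5-fold higher number from compound 3 to compound 4 (0.17 log units; within the scatter) is a modest loss, not clearly beyond the scatter. Compound 4 is therefore estimated at 8000 nM, within a range from 2500 nM to 30000 nM.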

Compound 4, half-maximal inhibitory concentration: > 50000 nM
Compound 4 gave a limit, no number (the forecaster's own chance of this, stated with the estimate: 20%); middle value at least 6.2-fold (0.79 log units) from the limit.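

Among these compounds, on the aromatic nitrogen of the five-membered ring, the exchange of 3-(trifluoromethyl)phenyl for 2,6-diethylphenyl gives the first readable step at this position; in this assay the step is an at least 9.2-fold higher number from compound 3 to compound 4 (0.96 log units; beyond the scatter). The earlier exchange on this nitrogen could not be read, whereas here, on one shared core, the change of this group alone separates a measured number from a limit, even though the leaving and entering groups have the same count of heavy atoms, hydrogen-bond donors and hydrogen-bond acceptors. Compound 4 stands at a limit and not at a number, so the step sets only a lower bound on the size of the change: the limit of > 50000 nM in this assay, at which 3 of the 4 values shown sit.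

The compounds shown do not tell whether the step comes from the loss of the trifluoromethyl group or from the arrival of the two ethyl groups, and a plain phenyl, or a phenyl carrying a single ethyl or methoxy group, on the core of compound 3 would bear on that question. They also leave open whether the 3-(trifluoromethyl)phenyl group would give a number on the core of compound 1.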